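This account rests on a few compounds, and the source may have more. Where it says the series, first, only, none or still open, it means among the compounds named here.

Measured so far:
- compound 1, `NC(=O)CN1CCN(c2nc(-c3cccnc3)nc3c2CN(Cc2ccccc2)CC3)CC1`: 100000 nM
- compound 2, `CN(C)CCN1CCN(c2nc(-c3ccccn3)nc3c2CN(C(=O)c2ccccc2)CC3)CC1`: 100000 nM
- compound 3, `Cc1cc(C)c2cc(C#N)c(NCCCNC(=O)c3ccncc3)nc2c1`: 13200 nM

All three were tested in an assay on cells with Cystic fibrosis transmembrane conductance regulator variant F508del (Homo sapiens) as the target, read by fluorescence, with stated times of 24 h and 30 min; a lower number here means that less compound is needed, a higher number that more compound is needed for the effect. In this assay compound 2 gives 100000 nM, and compound 1 gives 100000 nM, so the two stand level at the digits shown and together hold the highest numbers of the three. Compound 3, built on a different core, gives 13200 nM, a number well below that of compound 2, and the gap between these two lies beyond the scatter of the assay.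

The next compound, compound 4, `COc1ccc(CN2CCc3nc(-c4ccccn4)nc(N4CCN(CCN(C)C)CC4)c3C2)cc1`, has not yet been measured in this assay. It keeps the core and the side chains of compound 2 and differs in one place: 4-methoxybenzyl in place of benzoyl on an amine nitrogen in a ring

Going by the values given here, no step between two measured compounds that differ only in this way is available, so the size of the change cannot be read off directly. Compound 1, which carries a benzyl group on the same ring nitrogen together with other differences, gives 100000 nM, the same as compound 2, so nothing seen so far points to a large shift. For compound 4 the expected step is a 1.3-fold lower number from compound 2 to compound 4 (0.10 log units; within the scatter), small and within the usual scatter. Compound 4 is therefore expected to give about 80000 nM, with a range from 20000 nM to 150000 nM.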

Compound 4, half-maximal effective concentration: 100000 nM
Compound 4: middle estimate off by 1.3-fold (0.10 log units), on the low side; low and high end bracket the measured number.
By their numbers in this assay, from the lowest: compound 3; then compounds 1, 2 and 4 (each within the scatter of the next).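

In this assay, going by these compounds alone, putting 4-methoxybenzyl in place of benzoyl on the amine nitrogen in a ring gives no change at the digits printed from compound 2 to compound 4 (within the scatter), the first direct reading at this position with the rest of the molecule held fixed. The swap removes the carbonyl of the benzoyl group and adds a methoxy group to the aromatic ring, yet with this core and these side chains it leaves the number where it was, so this exchange alone does not reduce the amount of compound needed. No measurement is at hand that would explain this absence of change.

From the compounds shown here alone, it remains open whether a quite different group on this ring nitrogen, such as a small methyl, a chain ending in an amine or a carboxylic acid, or a longer chain ending in the same aromatic ring, would move the number. Within the data shown here, it is also open whether the same swap would give the same result with other groups elsewhere on the shared core, since only this one pair of compounds isolates the change.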